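The compounds below may be only part of what the source reports. "The series", "measured", "known", "first", "only" and "open" are said of these compounds alone.

Compound 1, with the structure `Cc1ccc([C@]2(CO)NC[C@@H](O)[C@@H]2O)cc1`, is the starting point here. In an assay on isolated protein for inhibition of alpha-mannosidase (Canavalia ensiformis), tested at 1000 uM (a higher number here means more inhibition at the concentration tested (going by the name of the read-out), a lower number less inhibition), compound 1 gives 0%, a reading that shows essentially no inhibition at the concentration tested. Its mirror image, compound 3 with the structure `Cc1ccc([C@@]2(CO)NC[C@H](O)[C@H]2O)cc1`, gives 0% in this assay, and the step of no change at the digits printed from compound 1 to compound 3 (within the scatter) is no change within the scatter; the only thing that separates these two is the fact that compounds 1 and 3 differ only in the configuration as drawn. The third measured compound, compound 2 with the structure `CCCC[C@]1(CO)NC[C@@H](O)[C@@H]1O`, carries a butyl chain in place of the aromatic ring and gives 1.9% in this assay, a number that sits within the scatter of the values of compound 1 and compound 3. So compound 1 stands level with compound 3, and compound 2 is indistinguishable from both on the numbers shown.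

The unmeasured compound 4 has the structure `OC[C@@]1(c2ccc(O)cc2)NC[C@@H](O)[C@@H]1O`. It differs from compound 1 by hydroxy in place of methyl on an aromatic carbon. Among the compounds with values here, none of the measured steps swaps a methyl for a hydroxy, so the only guidance is that every number so far sits near the floor of the read-out. The step of a number 1 percentage points higher from compound 1 to compound 4 (within the scatter) is therefore expected to stay within the scatter. For compound 4 in this assay the estimate is 1%, with a range from 0% to 10%.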

Compound 4, a percentage reported as inhibition, at one concentration (the size of the read-out at that concentration, not a potency): 2.2%
Beside the measured number, compound 4's estimate is 1.2 percentage points below it; the range from low to high includes it.
By their numbers in this assay, from the lowest: compounds 1, 3, 2 and 4 (each within the scatter of the next).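

In this assay, the aromatic carbon para to a group of 9 heavy atoms now has a first probe, and the result is a number 2.2 percentage points higher from compound 1 to compound 4 (within the scatter). Within the data shown here, replacing methyl with hydroxy adds a hydrogen-bond donor and a hydrogen-bond acceptor at this position, yet the reading stays near the floor, so this single-atom swap gives no sign of inhibition that the earlier compounds lacked. Nothing shown explains this outcome, since the only fact on record concerns configuration and has no bearing on a change from methyl to hydroxy.

Going by these compounds, it remains open whether an amine, a carboxylic acid or a methoxy group on the same aromatic carbon would give a reading clearly above the floor in this assay. With all four compounds so close to the floor, it is also unclear whether the choice between methyl and hydroxy would matter at all on a related compound that shows real inhibition, so this position can be judged only from a starting point with a clear signal.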